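Solubility of compound 3 and its 4-(methylsulfanyl)phenyl analogue

This account rests on a few compounds, and the source may have more. Where it says the series, first, only, none or still open, it means among the compounds named here.

Measured in a physicochemical assay for solubility, read by nephelometry, at pH 7.4; on this read-out higher numbers stand for higher solubility and lower numbers for lower solubility:
Compound 1 `COc1cccc(NC(=O)c2nnn(CC3CCN(C(C)=O)CC3)c2N)c1`: > 250000 nM (a limit)
Compound 2 `COc1cccc(NC(=O)c2nnn(Cc3ccc([S+](C)[O-])cc3)c2N)c1`: > 250000 nM (a limit)
Compound 3 `COc1cccc(NC(=O)c2nnn(Cc3cc(C)on3)c2N)c1`: 174000 nM

Going by the values given here, compound 3 carries the only number in this set, 174000 nM. The entries for compound 1 and compound 2 are limits of the assay and not numbers.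

The next compound is compound 4 `COc1cccc(NC(=O)c2nnn(Cc3ccc(SC)cc3)c2N)c1`, which has not yet been measured. It has 4-(methylsulfanyl)phenyl in place of 5-methyl-1,2-oxazol-3-yl on a saturated chain carbon bound to an aromatic nitrogen.

Two measured steps at this same place bear on it: an at least 1.4-fold lower number from compound 1 to compound 3 (0.15 log units; that floor lies within the scatter), and an at least 1.4-fold lower number from compound 2 to compound 3 (0.15 log units; that floor lies within the scatter). From the compounds shown here alone, their true sizes stay open because of the limit of > 250000 nM in this assay, at which 2 of the 3 values shown sit. The remaining step is a step that the two limits leave unreadable from compound 1 to compound 2, and it adds no size.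

None of these steps therefore gives a size to carry over. The expectation rests mainly on the structural change, in which a ring with hetero atoms leaves and a ring of carbon only enters, starting from the 174000 nM of compound 3. A moderate fall in this assay is expected, beyond the scatter but uncertain in size, and the estimate is a 2.9-fold lower number from compound 3 to compound 4 (0.46 log units; beyond the scatter). For compound 4 the expected value is 60000 nM, with an estimated range from 15000 nM to 200000 nM.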

Compound 4, solubility: < 12000 nM
Compound 4: only a limit was reported; the forecaster's own chance of this, stated with the estimate: 8%; at least 5.0-fold (0.69 log units) between middle value and limit.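

In this assay compound 4 gives < 12000 nM, which is a limit of the assay and not a number. At the saturated chain carbon bound to an aromatic nitrogen, the steps to compound 3 had shown only floors within the scatter, whereas 4-(methylsulfanyl)phenyl now gives a large drop: in place of 5-methyl-1,2-oxazol-3-yl it gives an at least 14-fold lower number from compound 3 to compound 4 (1.16 log units; beyond the scatter), and in place of 1-acetylpiperidin-4-yl it gives an at least 20-fold lower number from compound 1 to compound 4 (1.31 log units; beyond the scatter). The narrowest change shows that this position responds to a small edit, since the exchange of one group with no ring for another, on an aromatic carbon, gives an at least 20-fold lower number from compound 2 to compound 4 (1.31 log units; beyond the scatter).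

The full size of each of these steps stays open, as each has only a floor: the limit of < 12000 nM in this assay, at which 1 of the 4 values shown sits. Whether an amine or a carboxylic acid on that aromatic carbon, in place of the methylsulfanyl group, would give a read-out closer to that of compound 2 or to that of compound 4 is something the compounds shown cannot tell.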